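A few compounds are considered here, and "the series" means these few. Any claim that something is new, unique, unknown or untested is made for them only; others in the source may bear on it.

Measured compounds:
compound 1, `NC(=O)NC[C@@H]1CCCc2cc(S(=O)(=O)c3cccc(F)c3)ccc21` — 0.2 nM
compound 2, `CC(C)(O)C(=O)NC[C@@H]1CCCc2cc(S(=O)(=O)c3cccc(F)c3)ccc21` — 2 nM

Compound 2 stands highest of the two numbers measured in an assay on isolated protein for displacement of a labelled ligand from 5-hydroxytryptamine receptor 6 (Homo sapiens); a lower number here means a stronger inhibitor, a higher number a weaker inhibitor; its nearest neighbour is compound 1, which sits a step lower. That step is the only one measured: a 10-fold higher number from compound 1 to compound 2 (1.00 log units; beyond the scatter), a change of 1-hydroxy-1-methylethyl in place of amino on a carbonyl carbon.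

Compound 3, `NS(=O)(=O)NC[C@@H]1CCCc2cc(S(=O)(=O)c3cccc(F)c3)ccc21`, has not yet been measured in this assay. The change it makes is sulfamoyl in place of (1-hydroxy-1-methylethyl)carbonyl on an amine nitrogen. The measured step from compound 1 to compound 2 bears on this change indirectly: compound 1 carries a terminal amino on its carbonyl, and compound 3 carries a terminal amino on its sulfur, so compound 3 resembles compound 1 more than it resembles compound 2 at the end of the chain. Going by the values given here, the step in this assay is therefore expected to run downward, roughly reversing the loss seen from compound 1 to compound 2, though the sulfur-for-carbon exchange has no measured precedent here. The expected step is a 4.0-fold lower number from compound 2 to compound 3 (0.60 log units; beyond the scatter). Compound 3 is estimated at 0.5 nM, within a range from 0.1 nM to 3 nM.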

Compound 3, inhibition constant: 0.126 nM
The estimate for compound 3 lay 4.0-fold (0.60 log units) above the measured number; measured number inside the range.
By their numbers in this assay, from the lowest: compounds 3 and 1 (each within the scatter of the next); then compound 2.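

Compound 3 shows that the sulfamoyl group on this amine nitrogen gives a 16-fold lower number from compound 2 to compound 3 (1.20 log units; beyond the scatter) in this assay and so removes the loss that compound 2 carries with its (1-hydroxy-1-methylethyl)carbonyl group. The change of carbamoyl to sulfamoyl gives a 1.6-fold lower number from compound 1 to compound 3 (0.20 log units; within the scatter) and so leaves the two groups indistinguishable at this position, which means that a sulfur-centred group with a terminal amino serves here as well as the carbon-centred one. Across these three compounds, the two groups that end in amino lie within the scatter of each other and the one that ends in 1-hydroxy-1-methylethyl stands apart, though no measurement available here explains this difference.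

What remains open is whether the terminal amino itself matters, since neither a methanesulfonyl nor an acetyl group, each of which would replace that amino with a methyl, appears among these compounds. It is also unclear how far the sulfamoyl group tolerates substitution, as a methyl or a longer chain on its terminal nitrogen would test, and whether a carboxylic acid or an amine at the end of the chain would be accepted.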